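Swapping the Aryl Group on the Sulfonyl Sulfur of Compound 2

The source may report more compounds than this note shows. Statements on the series, on what has been measured and on what is new or still open speak of the compounds shown alone.

In a functional assay on A549 cells (Homo sapiens) for antiproliferative activity, read by MTT assay, with a stated time of 72 h (on this read-out lower numbers stand for stronger inhibition and higher numbers for weaker inhibition), compound 2 `Cc1ccc(S(=O)(=O)NC(=N)N2CCN(c3cc4c(cc3F)c(=O)c(C(=O)O)cn4C3CC3)CC2)cc1` gives 71 nM. Compound 2 stands level with compound 1 `N=C(NS(=O)(=O)c1ccccc1)N1CCN(c2cc3c(cc2F)c(=O)c(C(=O)O)cn3C2CC2)CC1`, at 71 nM, and with compound 3 `CCn1cc(C(=O)O)c(=O)c2cc(F)c(N3CCN(C(=N)NS(=O)(=O)c4cccc(Cl)c4)CC3)cc21`, at 71 nM.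

The unmeasured compound 4 `N=C(NS(=O)(=O)c1ccccc1Cl)N1CCN(c2cc3c(cc2F)c(=O)c(C(=O)O)cn3C2CC2)CC1` differs from compound 2 in one place: 2-chlorophenyl in place of 4-methylphenyl on a sulfonyl sulfur. In words, this is 2-chlorophenyl in place of 4-methylphenyl on a sulfonyl sulfur.

Among the compounds with values here, only one measured step touches this group, and it is small: no change at the digits printed from compound 1 to compound 2 (within the scatter). Compound 3 also carries a chlorine-bearing phenyl group on the sulfonyl sulfur and gives 71 nM, but it differs from compound 4 elsewhere as well, so it offers only indirect support. Within the data shown here, no measured compound carries the 2-chlorophenyl group itself, so the data leave this exact change untested.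

With all three measured values level, no shift beyond the scatter is expected in this assay, and no direction can be favoured. The expected outcome is no change at the digits printed from compound 2 to compound 4 (within the scatter). Compound 4 is estimated at 71 nM, with an expected range from 32 nM to 155 nM.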

Compound 4, half-maximal inhibitory concentration: 71 nM
Estimate against measurement, compound 4: no gap at the digits printed; the measured number falls inside the stated range.
By their numbers in this assay, from the lowest: compounds 1, 2, 3 and 4 (each within the scatter of the next).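

In this assay, the 2-chlorophenyl group on the sulfonyl sulfur gives no change at the digits printed from compound 2 to compound 4 (within the scatter), and the matching replacement of hydrogen by chloro on an aromatic carbon gives no change at the digits printed from compound 1 to compound 4 (within the scatter). Within the data shown here, until now, the only readable step at this aryl group was the methyl step, so these two steps extend the flat result to a second kind of substituent: among compounds 1, 2 and 4, the phenyl, 4-methylphenyl and 2-chlorophenyl groups can be exchanged on this core with no shift beyond the scatter. No supporting data bear on why these values stay level, and the three compounds alone cannot explain it.

The compounds shown leave open whether this tolerance extends beyond small substituents on a phenyl ring, for example to a phenyl ring bearing an amine or a carboxylic acid, to a naphthyl group, or to a longer alkyl chain in place of the aryl group on the sulfonyl sulfur. They also leave open whether any group at this position would move the value beyond the scatter, since every step shown here stays within it.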